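The source may report more compounds than this note shows. Statements on the series, on what has been measured and on what is new or still open speak of the compounds shown alone.

Measured so far in a functional assay on HCT-116 cells (Homo sapiens) for inhibition, read by MTT assay, with a stated time of 24 h, tested at 5 uM; a lower number here means less inhibition of growth, a higher number more inhibition of growth at the concentration tested:

- compound 1 `N#Cc1ccc(-c2cnc3[nH]cc(-c4nnc(-c5ccc(F)cc5)o4)c(=O)c3c2)cc1` gives 12.6%
- compound 2 `CS(=O)(=O)c1ccc(-c2cnc3[nH]cc(-c4nnc(-c5ccccc5)o4)c(=O)c3c2)cc1` gives 8.6%
- compound 3 `CS(=O)(=O)c1ccc(-c2cnc3[nH]cc(-c4nnc(-c5ccc(Cl)cc5)o4)c(=O)c3c2)cc1` gives 16.4%

Compound 3 carries the highest of the three numbers, but its gaps to compound 1 and to compound 2 both lie within the scatter, so no ordering among the three can be read from these data. Going by the values given here, the only step between two compounds differing in one place is a number 7.8 percentage points higher from compound 2 to compound 3 (within the scatter), chloro in place of hydrogen on an aromatic carbon, and it stays within the scatter.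

Compound 4 `N#Cc1ccc(-c2cnc3[nH]cc(-c4nnc(-c5ccc(Cl)cc5)o4)c(=O)c3c2)cc1` is the next member. It differs from compound 3 by cyano in place of methylsulfonyl on an aromatic carbon. Among the compounds with values here, no measured step tests this exchange directly. What bears on it is indirect: compound 1 and compound 3 differ in both the group on this ring and the halogen on the other ring, and their values in this assay lie within the scatter of each other, which gives no sign that either change moves the number much.

Compound 4 is therefore expected to remain close to compound 3, with an estimated step of a number 2.4 percentage points lower from compound 3 to compound 4 (within the scatter), none beyond the scatter. The estimate for compound 4 in this assay is 14%, with a range from 4% to 25%.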

Compound 4, percent growth inhibition at one concentration: 17.9%
Compound 4: the middle estimate sits 3.9 percentage points below what was measured; low and high end bracket the measured number.
By their numbers in this assay, from the lowest: compounds 2, 1, 3 and 4 (each within the scatter of the next).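

In this assay, cyano in place of methylsulfonyl, on an aromatic carbon para to a large group, now has a direct reading with the chloro on the other ring held fixed: a number 1.5 percentage points higher from compound 3 to compound 4 (within the scatter). This shows that the smaller cyano group, with its one triple bond, and the larger methylsulfonyl group, with its two double bonds, cannot be told apart at this position in this chlorinated pair. With the 4-cyanophenyl group held fixed, chloro in place of fluoro reads a number 5.3 percentage points higher from compound 1 to compound 4 (within the scatter), so this halogen exchange cannot be separated from the scatter either, and no information on the cause of these small steps is available.

Still open, on these data alone, is whether any other group at this position, such as an amine, a carboxylic acid or a longer chain, would move the number in this assay beyond the scatter. As far as these compounds go, on the other ring only hydrogen, fluoro and chloro appear, so the reading for a methoxy group or an amine at that place also remains unknown.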